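Methoxy step in the 2-phenylethenyl amide series

This account rests on a few compounds, and the source may have more. Where it says the series, first, only, none or still open, it means among the compounds named here.

- compound 1 `C#Cc1cccc(Nc2ncnc3cc(NC(=O)/C=C/c4ccccc4)sc23)c1`: 2340 nM
- compound 2 `O=C(/C=C/c1ccccc1)Nc1cc2ncnc(Nc3ccc(F)c(Cl)c3)c2s1`: 2100 nM

Among the measured compounds shown here, in a functional assay on MDA-MB-231 cells (Homo sapiens) for antiproliferative activity, read by MTT assay, with a stated time of 48 h (on this read-out higher numbers stand for weaker inhibition and lower numbers for stronger inhibition), compound 2, at 2100 nM, stands level with compound 1, the only other measured number. That step, a 1.1-fold lower number from compound 1 to compound 2 (0.05 log units; within the scatter), lies within the scatter and concerns the group on a nitrogen on an aromatic ring. Compound 3 `COc1ccc(/C=C/C(=O)Nc2cc3ncnc(Nc4ccc(F)c(Cl)c4)c3s2)cc1` differs from compound 2 elsewhere: methoxy in place of hydrogen on an aromatic carbon, para to a large group. For the measured compounds named here, no measured step covers this place, so only a weak guide exists and no shift beyond the scatter is expected. The expected change is a 1.2-fold lower number from compound 2 to compound 3 (0.07 log units; within the scatter). For compound 3 the estimated value is 1800 nM, with an expected range of 700 nM to 4500 nM.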

Compound 3, half-maximal inhibitory concentration: 2600 nM
Estimate against measurement, compound 3: 1.4-fold (0.16 log units) below, within the range that was stated.
By their numbers in this assay, from the lowest: compounds 2, 1 and 3 (each within the scatter of the next).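

Phenyl to 4-methoxyphenyl gives a 1.2-fold higher number from compound 2 to compound 3 (0.09 log units; within the scatter) in this assay and is the first reading at this end of the molecule. With 2-(4-methoxyphenyl)ethenyl in place of 2-phenylethenyl, the added methoxy, para to a large group, leaves compound 3 within the scatter of compound 2, though this rests on a single pair. No evidence on the cause of this result is available.

From the compounds shown here alone, whether an amine, a carboxylic acid or a longer alkoxy chain at this place would move the number beyond the scatter stays open. Also open, going by these compounds, is whether methoxy reads the same alongside 3-ethynylphenyl on the nitrogen.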